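Cytotoxicity series: swapping the triazolyl side group for an amide

This account rests on a few compounds, and the source may have more. Where it says the series, first, only, none or still open, it means among the compounds named here.

Compound 1 `COC(=O)CC1CCN(C[C@H]2CN(c3ccc(-n4cc(-c5ccccn5)cn4)c(F)c3)C(=O)O2)CC1` and compound 2 `O=C1O[C@@H](Cn2ccnn2)CN1c1ccc(-n2cc(-c3ccccn3)cn2)c(F)c1` share one core and differ only in the group carried on the saturated chain carbon bound to a saturated ring carbon. Going by the values given here, in an ADME assay on HEK293-A cells (Homo sapiens) for cytotoxicity, read by MTT assay, with a stated time of 48 h (a lower number here means a stronger inhibitor, a higher number a weaker inhibitor), compound 1 gives 224 ug/mL, and compound 2 gives 225 ug/mL, so compound 2 sits level with the only other measured compound; the step of a 1.0-fold higher number from compound 1 to compound 2 (0.00 log units; within the scatter) shows no movement beyond the scatter.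

Compound 3 `CCC(=O)NC[C@H]1CN(c2ccc(-n3cc(-c4ccccn4)cn3)c(F)c2)C(=O)O1` continues from compound 2 by the change (propanoylamino in place of 1H-1,2,3-triazol-1-yl on a saturated chain carbon bound to a saturated ring carbon). Among the compounds with values here, the one measured step at this same place, from compound 1 to compound 2, left this assay unchanged even though a ring-bearing group was exchanged for a small aromatic ring. On that basis the expected step of a 1.0-fold lower number from compound 2 to compound 3 (0.01 log units; within the scatter) is none beyond the scatter. Compound 3 is therefore estimated at 220 ug/mL in this assay, with a range from 110 ug/mL to 440 ug/mL.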

Compound 3, half-maximal inhibitory concentration: 389 ug/mL
Compound 3: the middle estimate sits 1.8-fold (0.25 log units) below what was measured; low and high end bracket the measured number.
By their numbers in this assay, from the lowest: compounds 1, 2 and 3 (each within the scatter of the next).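

In this assay, replacing 1H-1,2,3-triazol-1-yl with propanoylamino gives a 1.7-fold higher number from compound 2 to compound 3 (0.24 log units; within the scatter), and replacing 4-((methoxycarbonyl)methyl)piperidin-1-yl with propanoylamino gives a 1.7-fold higher number from compound 1 to compound 3 (0.24 log units; within the scatter). Going by these compounds alone, the tolerance seen so far on this saturated chain carbon therefore extends from two ring-bearing groups to a group with no ring and with one hydrogen-bond donor, as no step among the three compounds leaves the scatter. No supporting data bear on this result.

Open, from the compounds shown here alone, is whether an amine, a carboxylic acid or a longer chain on this carbon would also stay within the scatter. The compounds shown also leave open whether any change elsewhere on the shared core would move the number in this assay.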